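Chain extension on the fluorinated analogue of the series

This account rests on a few compounds, and the source may have more. Where it says the series, first, only, none or still open, it means among the compounds named here.

Values recorded in a functional assay on A549 cells (Homo sapiens) for inhibition, read by CCK-8 assay, with a stated time of 72 h, tested at 10 uM; on this read-out lower numbers stand for a weaker effect and higher numbers for a stronger effect at the one concentration tested:

compound 1, `CN(C)C(=O)c1cc2cnc(Nc3ccc(C(=O)NCCCN=C=S)cc3)nc2n1C1CCCC1`: 103%
compound 2, `CN(C)C(=O)c1cc2cnc(Nc3ccc(C(=O)NCCCCN=C=S)cc3)nc2n1C1CCCC1`: 102%
compound 3, `CN(C)C(=O)c1cc2cnc(Nc3ccc(C(=O)NCCCN=C=S)cc3F)nc2n1C1CCCC1`: 60.2%

Compound 3 stands lowest of the three numbers in this assay. Its nearest neighbour is compound 2, and the gap from compound 3 to compound 2 lies beyond the scatter; the gap to compound 1 is larger still, shown directly as a number 42.8 percentage points lower from compound 1 to compound 3 (beyond the scatter), the one change there being fluoro in place of hydrogen on an aromatic carbon.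

Compound 4, `CN(C)C(=O)c1cc2cnc(Nc3ccc(C(=O)NCCCCN=C=S)cc3F)nc2n1C1CCCC1`, is not yet measured. It differs from compound 3 by a group of 4 heavy atoms (2 carbon, 1 nitrogen, 1 sulfur; no ring) in place of a group of 3 heavy atoms (1 carbon, 1 nitrogen, 1 sulfur; no ring), on a saturated chain carbon, three bonds along the chain from an amide-type nitrogen.

Among the measured compounds shown here, the one measured step of the same kind is a number 1 percentage points lower from compound 1 to compound 2 (within the scatter), which lies within the scatter. Compound 4 is therefore expected to sit close to compound 3 in this assay, with no step beyond the scatter in either direction, so that the estimated step is a number 1.2 percentage points lower from compound 3 to compound 4 (within the scatter). For compound 4 the estimate in this assay is 59%, with a range from 40% to 78%.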

Compound 4, a percentage reported as inhibition, at one concentration (the size of the read-out at that concentration, not a potency): 24.4%
Compound 4: the middle estimate sits 34.6 percentage points above what was measured, outside the stated range (below it).
By their numbers in this assay, from the lowest: compound 4; then compound 3; then compounds 2 and 1 (each within the scatter of the next).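

Chain length at this position matters only on the fluoro core in this assay: the added chain carbon gives a number 35.8 percentage points lower from compound 3 to compound 4 (beyond the scatter), a sensitivity that compounds 1 and 2 gave no sign of. The two changes therefore do not act independently across these four compounds, and the pairs compare as follows: the same change on two cores in this assay, a number 1 percentage points lower (within the scatter) from compound 1 to compound 2 and a number 35.8 percentage points lower (beyond the scatter) from compound 3 to compound 4, 34.8 percentage points apart, beyond the scatter of two such steps.

Read the other way, fluoro in place of hydrogen on an aromatic carbon costs more on the longer chain, with a number 77.6 percentage points lower from compound 2 to compound 4 (beyond the scatter), and this step also differs from its shorter-chain counterpart: the same change on two cores in this assay, a number 42.8 percentage points lower (beyond the scatter) from compound 1 to compound 3 and a number 77.6 percentage points lower (beyond the scatter) from compound 2 to compound 4, 34.8 percentage points apart, beyond the scatter of two such steps.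

As far as these compounds go, it remains open whether a longer chain on the fluoro core would lower the number further, and whether chloro in place of fluoro would show the same dependence on chain length. Each number is the size of the effect at one concentration, so these comparisons show only a stronger or weaker effect at that concentration.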